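Notes on the Ring Exchange from Compound 1 to Compound 4

The compounds below may be only part of what the source reports. "The series", "measured", "known", "first", "only" and "open" are said of these compounds alone.

Compound 1 `N#Cc1c(N)nc(SCc2ncn[nH]2)c(C#N)c1-c1ccc(OCC2CC2)cc1` gives 338 nM in an assay on CHO cells for displacement of a labelled ligand from adenosine receptor A1 (Homo sapiens), read by scintillation counting, with a stated time of 90 min; on this read-out lower numbers stand for stronger inhibition and higher numbers for weaker inhibition. Among the three measured compounds it holds the second highest number: compound 3 `C=CCOc1ccc(-c2c(C#N)c(N)nc(SCC(N)=O)c2C#N)cc1`, with 323 nM, lies within the scatter of compound 1, while compound 2 `C=C(C)COc1ccc(-c2c(C#N)c(N)nc(SCC(N)=O)c2C#N)cc1`, with 872 nM, stands beyond it. Going by the values given here, the single step between neighbours that differ in one place is a 2.7-fold lower number from compound 2 to compound 3 (0.43 log units; beyond the scatter), where hydrogen replaces methyl on a double-bonded chain carbon bound to a saturated chain carbon, on the ether side of the shared core.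

Compound 4 `N#Cc1c(N)nc(SCC2=NCCN2)c(C#N)c1-c1ccc(OCC2CC2)cc1` differs from compound 1 as follows: a group of 5 heavy atoms (3 carbon, 2 nitrogen; one five-membered non-aromatic ring with 2 hetero atoms) in place of a group of 5 heavy atoms (2 carbon, 3 nitrogen; one five-membered aromatic ring with 3 hetero atoms), on a saturated chain carbon bound to a sulfur. The group that enters matches the group that leaves in the count of heavy atoms, hydrogen-bond donors and hydrogen-bond acceptors, but the five-membered ring is non-aromatic and carries two hetero atoms rather than three. Among the compounds with values here, no measured step touches the saturated chain carbon bound to a sulfur, so the one measured step gives no direct guide here; it only shows that single-group changes have so far stayed modest. The expectation for compound 4 is therefore a step of a 1.2-fold higher number from compound 1 to compound 4 (0.07 log units; within the scatter), that is, no change beyond the scatter. Compound 4 is estimated at 400 nM, within 150 nM to 1100 nM.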

Compound 4, inhibition constant: 483 nM
Compound 4: the middle estimate sits 1.2-fold (0.08 log units) below what was measured; low and high end bracket the measured number.
By their numbers in this assay, from the lowest: compounds 3, 1, 4 and 2 (each within the scatter of the next, the first and the last beyond it).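

In this assay, going by these compounds alone, the first measured exchange on the saturated chain carbon bound to a sulfur gives a 1.4-fold higher number from compound 1 to compound 4 (0.16 log units; within the scatter). This position therefore accepts the five-membered non-aromatic ring with 2 hetero atoms in place of 1H-1,2,4-triazol-5-yl without a shift beyond the scatter, even though the aromatic ring is lost and a ring nitrogen is replaced by carbon in the same step; the two entries match in heavy atoms, hydrogen-bond donors and hydrogen-bond acceptors, so this exchange does not test those counts. No measurement in hand explains why the number stays within the scatter, and the loss of aromaticity cannot be separated from the change in hetero atoms.

The compounds shown leave open whether this tolerance extends to groups that differ in size or in hydrogen-bond counts, such as a carboxylic acid, a primary amine, a six-membered pyridine ring or a longer chain on the same carbon. They also leave open how the amide of compound 2 and compound 3 compares with these rings at this position, since both compounds also differ from compound 1 and compound 4 on the ether side of the shared core.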